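The compounds below may be only part of what the source reports. "The series", "measured", "known", "first", "only" and "open" are said of these compounds alone.

Of the compounds shown here, three that share one core have been tested in a functional assay on HT-29 cells (Homo sapiens) for cytotoxicity, read by MTT assay; on this read-out lower numbers stand for stronger inhibition and higher numbers for weaker inhibition. Compound 1 `C=C1C(=O)[C@]23C[C@@]1(Cl)CC[C@H]2[C@@]12C=CC(=O)[C@](C)(C(=O)O1)[C@H]2[C@@H]3C(=O)OC`, which carries chloro, gives 2900 nM. Compound 2 `C=C1C(=O)[C@]23C[C@@]1(O)CC[C@H]2[C@@]12C=CC(=O)[C@](C)(C(=O)O1)[C@H]2[C@@H]3C(=O)OC`, which carries hydroxy, gives 65700 nM. Compound 3 `C=C1C(=O)[C@]23C[C@@]1(F)CC[C@H]2[C@@]12C=CC(=O)[C@](C)(C(=O)O1)[C@H]2[C@@H]3C(=O)OC`, which carries fluoro, gives 72700 nM. Compound 3 therefore sits at the high end of the numbers, alongside compound 2, and the two cannot be told apart: a 1.1-fold higher number from compound 2 to compound 3 (0.04 log units; within the scatter). Only the chloro compound stands apart, as two large steps show: a 23-fold higher number from compound 1 to compound 2 (1.36 log units; beyond the scatter) and a 25-fold higher number from compound 1 to compound 3 (1.40 log units; beyond the scatter).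

Compound 4 `C=C1C(=O)[C@]23C[C@@]1(I)CC[C@H]2[C@@]12C=CC(=O)[C@](C)(C(=O)O1)[C@H]2[C@@H]3C(=O)OC` has iodo in place of fluoro on a saturated ring carbon. For the measured compounds named here, no iodo compound has been measured, so the nearest guide is the other swap of fluoro for a halogen, the step of a 25-fold higher number from compound 1 to compound 3 (1.40 log units; beyond the scatter) read in reverse. Going by the values given here, this is only one precedent, and iodo may not behave like chloro. A large move towards a lower number therefore seems likely, though with wide uncertainty. The expected change is an 18-fold lower number from compound 3 to compound 4 (1.26 log units; beyond the scatter), which is an estimate. For compound 4, the estimated value is 4000 nM, with an expected range from 900 nM to 20000 nM.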

Compound 4, half-maximal inhibitory concentration: 51900 nM
For compound 4 the middle estimate is 13-fold (1.11 log units) below the measured one; measured number outside the range, above it.
By their numbers in this assay, from the lowest: compound 1; then compounds 4, 2 and 3 (each within the scatter of the next).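

In this assay iodo does not share the standing of chloro on this saturated ring carbon: compound 4 stays well apart from the chloro compound (an 18-fold higher number from compound 1 to compound 4 (1.25 log units; beyond the scatter)) and cannot be told apart from the fluoro compound (a 1.4-fold lower number from compound 3 to compound 4 (0.15 log units; within the scatter)) or the hydroxy compound (a 1.3-fold lower number from compound 2 to compound 4 (0.10 log units; within the scatter)). Chloro is therefore the only one of the four groups that stands apart, and the presence of a halogen at this carbon does not by itself bring the lower number seen for compound 1. Nothing available here explains why chloro alone differs.

From the compounds shown here alone, whether bromo would group with chloro or with fluoro and iodo remains open. So does what plain hydrogen, a methoxy group or an amine would give on this same carbon.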